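This account rests on a few compounds, and the source may have more. Where it says the series, first, only, none or still open, it means among the compounds named here.

Measured compounds:
compound 1 `NS(=O)(=O)c1ccc(-n2nc(-c3ccc(Cl)cc3)cc2-c2cc(O)ccc2O)cc1`: 61400 nM
compound 2 `CC(=O)NS(=O)(=O)c1ccc(-n2nc(-c3ccccc3)cc2-c2cc(O)ccc2O)cc1`: 100000 nM
compound 3 `NS(=O)(=O)c1ccc(-n2nc(-c3ccc(Cl)cc3)cc2C2=CC(=O)C=CC2=O)cc1`: 84600 nM

These three compounds were tested in a functional assay on cells (Leukemia cell, Homo sapiens) for cytotoxicity, read by sulforhodamine B assay, with a stated time of 48 h; on this read-out lower numbers stand for stronger inhibition of growth and higher numbers for weaker inhibition of growth. Compound 1 and compound 3 share a core and differ in one place: a group of 8 heavy atoms (6 carbon, 2 oxygen; one six-membered non-aromatic ring of carbon only) in place of a group of 8 heavy atoms (6 carbon, 2 oxygen; one six-membered aromatic ring of carbon only), on an aromatic carbon. This change gave a 1.4-fold higher number from compound 1 to compound 3 (0.14 log units; within the scatter). Compound 2 is built on a core that differs from that of compound 1; the difference between the two cores is not broken down here. Compound 2 has the highest of the three values, but its values against compound 1 and compound 3 lie within the scatter.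

Compound 4 `CC(=O)NS(=O)(=O)c1ccc(-n2nc(-c3ccccc3)cc2C2=CC(=O)C=CC2=O)cc1` is not yet measured in this assay. It differs from compound 2 by the same kind of change: a group of 8 heavy atoms (6 carbon, 2 oxygen; one six-membered non-aromatic ring of carbon only) in place of a group of 8 heavy atoms (6 carbon, 2 oxygen; one six-membered aromatic ring of carbon only), on an aromatic carbon. Around the place the surroundings differ: in compound 1 the neighbouring ring atom bears a 4-sulfamoylphenyl group and the ring atom two bonds away bears a 4-chlorophenyl group, whereas in compound 2 the neighbouring ring atom bears a large group and the ring atom two bonds away bears a phenyl group.

Because a 1.4-fold higher number from compound 1 to compound 3 (0.14 log units; within the scatter) was within the scatter, compound 4 is expected to give about no change at the digits printed from compound 2 to compound 4 (within the scatter). The expected value for compound 4 is 100000 nM, between 50000 nM and 200000 nM.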

Compound 4, concentration for total growth inhibition: 91200 nM
Compound 4: middle estimate off by 1.1-fold (0.04 log units), on the high side, within the range that was stated.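

In this assay, putting the non-aromatic ring in place of the 2,5-dihydroxyphenyl group gave a 1.1-fold lower number from compound 2 to compound 4 (0.04 log units; within the scatter), so on this second core, as on the first, the exchange produced no step beyond the scatter. The two cores therefore agree as far as these data can tell: the same change on two cores in this assay, a 1.4-fold higher number (0.14 log units; within the scatter) from compound 1 to compound 3 and a 1.1-fold lower number (0.04 log units; within the scatter) from compound 2 to compound 4, 1.5-fold (0.18 log units) apart, within the scatter of two such steps. This shows that the exchange carried over without a readable difference between these two cores, but it does not show that the same would hold on other cores, and steps this small cannot reveal a modest dependence on the core.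

On these data alone, the chlorine on the phenyl group and the acetyl group on the sulfamoyl nitrogen stand together as the difference between the two cores, so what each contributes alone remains open. Also open, as far as these compounds go, is how the read-out would respond to a different group at this place, such as an amine or a carboxylic acid.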